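Chain Aryl Groups in Homoserine Lactone Amides on Prostate Cells

The source may report more compounds than this note shows. Statements on the series, on what has been measured and on what is new or still open speak of the compounds shown alone.

Compound 1, `O=C(CCCCCCCCCCc1ccccc1)N[C@H]1CCOC1=O`: in a functional assay on PC-3 cells (Homo sapiens) for cytotoxicity, read by sulforhodamine B assay, with a stated time of 5 days (a lower number here means a stronger inhibitor, a higher number a weaker inhibitor), compound 1 gives 66000 nM.
Compound 2, `O=C(CCCCCCCCCCCc1ccccc1)N[C@H]1CCOC1=O`: compound 2 reports only a limit, > 100000 nM.
Compound 3, `O=C(CCCCCCCCCc1ccccc1)CC(=O)N[C@H]1CCOC1=O`: compound 3 gives 4000 nM.

Compound 4, `O=C(CCCCCCCCc1ccccc1)CC(=O)N[C@H]1CCOC1=O`, is not yet measured in this assay. It differs from compound 3 by phenyl in place of benzyl on a saturated chain carbon, eight bonds along the chain from a carbonyl carbon. The same kind of change is already measured between compound 2 and compound 1, (phenyl in place of benzyl on a saturated chain carbon, ten or more bonds along the chain from a carbonyl carbon), where it gave an at least 1.5-fold lower number from compound 2 to compound 1 (0.18 log units; that floor lies within the scatter). The two places are not the same: the change to compound 4 sits nearer to the carbonyl carbon along the chain than the change between compound 2 and compound 1 does, as the two differences above show. How the core of compound 3 differs from that of compound 2 is not broken down here. Of the two measured numbers, compound 3 has the lowest. Since the measured step is small, a step of a 1.3-fold lower number from compound 3 to compound 4 (0.12 log units; within the scatter) is expected, resting on an at least 1.5-fold lower number from compound 2 to compound 1 (0.18 log units; that floor lies within the scatter). Compound 4 is estimated at 3000 nM, expected between 1200 nM and 8000 nM.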

Compound 4, half-maximal inhibitory concentration: 4000 nM
Estimate against measurement, compound 4: 1.3-fold (0.12 log units) below; the range from low to high includes it.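

In this assay, phenyl in place of benzyl on the core of compound 3 gives no change at the digits printed from compound 3 to compound 4 (within the scatter). Set beside the earlier step, this result shows no readable effect of the change on this core, but it does not establish that the change carries over from one core to the other with the same size, nor that it behaves differently: the same change on two cores in this assay, an at least 1.5-fold lower number (0.18 log units; that floor lies within the scatter) from compound 2 to compound 1 and no change at the digits printed (within the scatter) from compound 3 to compound 4; the limit leaves it open whether they differ. The earlier step rests on compound 2, whose value is a limit and not a number: the limit of > 100000 nM in this assay, at which 1 of the 4 values shown sits.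

The compounds shown leave open how a much shorter chain would read on either core. They also leave open what a carboxylic acid or an amine at the chain end, in place of the phenyl, would do.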